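The source may hold more compounds than are shown below. What is called first, only, known or untested is meant among the compounds shown, and "the series" means these compounds.

Working notes on the series. Compound 1 `CCCCCCOc1ccc(C(CC(=O)O)c2ccccc2)cc1` carries a hexyloxy chain on the shared core; in a functional assay on HEK293 cells for agonist activity at Free fatty acid receptor 1 (Homo sapiens), read by calcium flux (on this read-out lower numbers stand for an effect already at smaller amounts and higher numbers for an effect only at larger amounts of compound), compound 1 gives 2.88 uM. Compound 2 `C=C(C)CCOc1ccc(C(CC(=O)O)c2ccccc2)cc1` differs in one place, and in this assay compound 2 gives 2.71 uM. The step of a 1.1-fold lower number from compound 1 to compound 2 (0.03 log units; within the scatter) lies within the scatter, so compound 1 and compound 2 sit at the same level on this read-out and neither can be set above the other.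

Compound 3 `CC(C)CCOc1ccc(C(CC(=O)O)c2ccccc2)cc1` is not yet measured. It differs from compound 2 by isopropyl in place of 1-methylethenyl on a saturated chain carbon, two bonds along the chain from an oxygen on an aromatic ring. For the measured compounds named here, the only measured step that bears on it is the exchange of the saturated butyl for 1-methylethenyl at the same place, which gave a 1.1-fold lower number from compound 1 to compound 2 (0.03 log units; within the scatter), a change of no consequence on this assay. Saturating the double bond again is therefore expected to leave the number where it stands, a step of a 1.0-fold higher number from compound 2 to compound 3 (0.01 log units; within the scatter) at most. For compound 3 in this assay the expected value is 2.8 uM, with a range from 1.4 uM to 5.6 uM.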

Compound 3, concentration for half-maximal effect: 1.86 uM
The estimate for compound 3 lay 1.5-fold (0.18 log units) above the measured number, within the range that was stated.
By their numbers in this assay, from the lowest: compounds 3, 2 and 1 (each within the scatter of the next).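

In this assay, loss of the double bond at this position, on a saturated chain carbon two bonds along the chain from an oxygen on an aromatic ring, stays within the scatter, with a 1.5-fold lower number from compound 2 to compound 3 (0.16 log units; within the scatter) as the printed step. Isopropyl in place of butyl at the same place also stays within the scatter, with a 1.5-fold lower number from compound 1 to compound 3 (0.19 log units; within the scatter), so butyl, 1-methylethenyl and isopropyl now all sit at one level on this read-out, and all three pairs among the compounds are covered. No measured evidence accounts for this shared level.

As far as these compounds go, whether a longer chain, a cyclopropyl group or an amine at this place would hold that level remains open, as does whether any exchange here moves the number beyond the scatter. From the compounds shown here alone, the effect of replacing the carboxylic acid on the shared core is also open.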